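A few compounds are considered here, and "the series" means these few. Any claim that something is new, unique, unknown or untested is made for them only; others in the source may bear on it.

Compound 1 `Cc1cc(C#N)cn2c(CSCCc3ccccc3)cnc12`: 14 ug/mL
Compound 2 `Cc1cc(-c2ccco2)c2ncc(CSCCc3ccccc3)n2c1`: 41 ug/mL
Compound 3 `Cc1cc(-n2cccc2)c2ncc(CSCc3ccccc3)n2c1`: 15 ug/mL

In an ADME assay on HEL cells (Homo sapiens) for cytotoxicity, with a stated time of 3 days (on this read-out higher numbers stand for lower toxicity in this test and lower numbers for higher toxicity in this test), compound 2 gives 41 ug/mL, the highest of the three numbers. Compound 3 gives 15 ug/mL and compound 1 gives 14 ug/mL, and both of these lie beyond the scatter from the number of compound 2. Compound 4 `Cc1cc(-n2ccc3cccnc32)c2ncc(CSCCc3ccccc3)n2c1` has not yet been measured. It differs from compound 2 in a group of 9 heavy atoms (7 carbon, 2 nitrogen; one five-membered aromatic ring with 1 hetero atom, one six-membered aromatic ring with 1 hetero atom) in place of a group of 5 heavy atoms (4 carbon, 1 oxygen; one five-membered aromatic ring with 1 hetero atom), on an aromatic carbon. Within the data shown here, no measured pair in this set shows this change, so nothing direct is known about its effect. A moderate step downward in this assay is expected for compound 4, though no step beyond the scatter cannot be ruled out. Compound 4 is expected to give about 25 ug/mL, with a range from 8 ug/mL to 60 ug/mL. This estimate means a 1.6-fold lower number from compound 2 to compound 4 (0.21 log units; within the scatter).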

Compound 4, half-maximal cytotoxic concentration: > 100 ug/mL
Compound 4: a limit, no number (the forecaster's own chance of this, stated with the estimate: 10%); at least 4.0-fold (0.60 log units) between middle value and limit.
By their numbers in this assay, from the lowest: compounds 1 and 3 (each within the scatter of the next); then compound 2. At a limit, above all of these: compound 4.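

Among these compounds, this is the first step read at this aromatic carbon: with the furan-2-yl group replaced by the larger fused two-ring group, this assay shows an at least 2.4-fold higher number from compound 2 to compound 4 (0.38 log units; beyond the scatter). The larger group therefore brings no fall in the number here, and the read-out moves toward lower toxicity in this test. Compound 4 gives > 100 ug/mL, which is a limit and not a number.

On these data alone, how far compound 4 lies past that limit stays open. So does what an amine or a carboxylic acid on this same carbon would give.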